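Swapping a Nitrile for a Cyclohexyl on the Amine Arm

This account rests on a few compounds, and the source may have more. Where it says the series, first, only, none or still open, it means among the compounds named here.

Three compounds in this small set share a central amine nitrogen carrying a nitrothiophene-derived arm, and they were tested in a functional assay on HEK293 cells for agonist activity at nuclear receptor subfamily 1 group D member 1 (Homo sapiens), read by a luciferase reporter, with a stated time of 24 h; on this read-out higher numbers stand for an effect only at larger amounts of compound and lower numbers for an effect already at smaller amounts. Compound 1 `CC(C)(C)OC(=O)CN(Cc1ccc([N+](=O)[O-])s1)S(=O)(=O)c1cccc2ccccc12` gives 800 nM in this assay. Compound 2 `O=C(O)CN(Cc1ccc(Cl)cc1)Cc1ccc([N+](=O)[O-])s1` has a result recorded only as "not determined" (no result reported), so it offers no number. Compound 3 `N#CCN(Cc1ccc(Cl)cc1)Cc1ccc([N+](=O)[O-])s1` gives 2500 nM in this assay, which is the highest of the two numbers available; compound 1 sits closer to the low end, and the gap between them is larger than the usual scatter of repeated measurements.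

Compound 4 `O=[N+]([O-])c1ccc(CN(Cc2ccc(Cl)cc2)CC2CCCCC2)s1` is not yet measured. It differs from compound 3 in one place: cyclohexyl in place of cyano on a saturated chain carbon bound to an amine nitrogen, that is, cyclohexyl in place of cyano on the saturated chain carbon bound to the amine nitrogen. Within the data shown here, no measured pair in this set shows that exact change, so its effect can only be guessed from the two numbers in hand. Among the measured compounds shown here, replacing a small two-atom group by a six-carbon ring is a sizeable structural move, yet the data offer no direct precedent for it.

Compound 4 is expected to land at about 1500 nM, within 500 nM to 5000 nM. The expected step from compound 3 to compound 4, a 1.7-fold lower number from compound 3 to compound 4 (0.22 log units; within the scatter), points toward a somewhat lower number, though it may not clearly exceed the usual scatter.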

Compound 4, half-maximal effective concentration: 7400 nM
The estimate for compound 4 lay 4.9-fold (0.69 log units) below the measured number, and the stated range ends below it.
By their numbers in this assay, from the lowest: compound 1; then compound 3; then compound 4.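

In this assay, placing cyclohexyl in place of cyano on the saturated chain carbon bound to the amine nitrogen gives a 3.0-fold higher number from compound 3 to compound 4 (0.47 log units; beyond the scatter), so an effect now appears only at larger amounts of compound. Among these compounds, this is the first comparison in the set in which only one place changes, and it shows that the read-out is sensitive to what sits at this position: the cyclohexyl ring does not serve as a neutral stand-in for the cyano group, and here it gives up ground rather than gaining it. Nothing measured here accounts for this shift, so the data describe the size and direction of the step but not its cause.

This single step cannot separate the arrival of a larger group, the arrival of a ring and the loss of the hydrogen-bond acceptor, and compound 2, with its carboxylic acid, adds no number at this position. A smaller cyclopropyl ring, an open butyl chain or a phenyl ring in the same place could begin to show which of these differences matters.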